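The source may hold more compounds than are shown below. What is called first, only, known or untested is meant among the compounds shown, and "the series" means these compounds.

Among the measured compounds shown here, compound 1 `O=C(Nc1ccc(Oc2ccnc3[nH]ccc23)c(F)c1)c1cc2cccnc2n(-c2ccc(Br)cc2)c1=O` is the one member of this small set with a measured result: in a functional assay on NCI-H460 cells (Homo sapiens) for antiproliferative activity, read by MTT assay, with a stated time of 72 h (on this read-out higher numbers stand for weaker inhibition and lower numbers for stronger inhibition), compound 1 gives 260 nM. Compound 2 `O=C(Nc1ccc(Oc2ccnc3[nH]ccc23)c(F)c1)c1cc2cccnc2n(-c2ccc(C(F)(F)F)cc2Cl)c1=O` shares the same amide-linked core but carries a trifluoromethyl group and a chlorine on its outer phenyl ring where compound 1 carries a bromine; in this assay compound 2 is recorded as "not determined" (no result reported), so it stands nowhere on the numbers shown. Compound 3 `Cn1ccc2c(Oc3ccc(NC(=O)c4cc5cccnc5n(-c5ccc(C(F)(F)F)cc5Cl)c4=O)cc3F)ccnc21` is compound 2 with one further change, namely (methyl in place of hydrogen on an aromatic nitrogen).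

For the measured compounds named here, no measured pair shares exactly this change. No step size can therefore be drawn from the data. The most that can be said is an expectation: the change from compound 2 to compound 3 is expected to move the result in this assay toward weaker inhibition by a modest amount, possibly no more than the usual scatter. Compound 3 is therefore estimated at 450 nM, with a range from 90 nM to 3000 nM.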

Compound 3, half-maximal inhibitory concentration: 6010 nM
The estimate for compound 3 lay 13-fold (1.13 log units) below the measured number; the whole stated range lies below it.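

In this assay, among the compounds shown here, compound 2 has no number, so no step to compound 3 can be read. On these data alone, what methyl in place of hydrogen on the aromatic nitrogen does by itself stays open. Nothing shown here offers a measured explanation for the result of compound 3.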